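The source may hold more compounds than are shown below. What is called first, only, known or untested is meant among the compounds shown, and "the series" means these compounds.

Measured in a functional assay on MCF7 cells (Homo sapiens) for antiproliferative activity, read by MTT assay, with a stated time of 72 h; on this read-out lower numbers stand for stronger inhibition and higher numbers for weaker inhibition:
compound 1 `CCNC(=S)SCC1=CCOC1=O`: 80100 nM
compound 2 `CNC(=S)SCC1=CCOC1=O`: 83100 nM
compound 3 `O=C1OCC=C1CSC(=S)NCc1ccccc1`: 31900 nM

Compound 2 sits at the upper end of these numbers, without separation from its nearest neighbour: a 1.0-fold higher number from compound 1 to compound 2 (0.02 log units; within the scatter). Only the phenyl replacement stands apart, with a 2.6-fold lower number from compound 2 to compound 3 (0.42 log units; beyond the scatter) and a 2.5-fold lower number from compound 1 to compound 3 (0.40 log units; beyond the scatter).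

The next compound is compound 4 `O=C1OCC=C1CSC(=S)N1CCCC1`, and the change from compound 2 is pyrrolidin-1-yl in place of methylamino on a thiocarbonyl carbon. For the measured compounds named here, no measured step replaces methylamino with pyrrolidin-1-yl, so the evidence is indirect. All three measured steps alter the group on the same nitrogen. The hydrogen-for-methyl step stayed within the scatter, and the two phenyl steps were modest and went towards lower numbers. In this assay, a small shift towards a lower number is therefore expected, with no clear move beyond the scatter. The expected change is a 1.7-fold lower number from compound 2 to compound 4 (0.22 log units; within the scatter). Compound 4 is estimated at 50000 nM, with an expected range of 20000 nM to 120000 nM.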

Compound 4, half-maximal inhibitory concentration: 56400 nM
Beside the measured number, compound 4's estimate is 1.1-fold (0.05 log units) below it; measured number inside the range.
By their numbers in this assay, from the lowest: compounds 3, 4, 1 and 2 (each within the scatter of the next, the first and the last beyond it).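

In this assay, the thiocarbonyl carbon takes pyrrolidin-1-yl, with one five-membered non-aromatic ring and 0 hydrogen-bond donors, in place of methylamino with a 1.5-fold lower number from compound 2 to compound 4 (0.17 log units; within the scatter), and in place of ethylamino with a 1.4-fold lower number from compound 1 to compound 4 (0.15 log units; within the scatter). The earlier compounds shown here changed only the group carried on a nitrogen that kept its hydrogen, whereas here the hydrogen-bond donor is gone and the nitrogen sits in a ring, with neither step leaving the scatter. No data at hand bear on why these numbers stay together.

Open, going by these compounds, is whether piperidin-1-yl, morpholin-4-yl or an open-chain diethylamino group at the thiocarbonyl carbon would stay at this level. Also open, on these data alone, is whether a chloro or methoxy group on the phenyl ring of compound 3 would shift its number.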